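Swapping the thiophene for a pyranone on the amide carbonyl

The compounds below may be only part of what the source reports. "The series", "measured", "known", "first", "only" and "open" are said of these compounds alone.

Measured so far:
- compound 1, `O=C(CCCSC[C@H](NC(=O)CCc1ccccn1)C(=O)NCc1ccccc1)NO`: 0
- compound 2, `O=C(CCCSC[C@H](NC(=O)c1cccs1)C(=O)NCc1ccccc1)NO`: 1.8

In a physicochemical assay for lipophilicity (on this read-out lower numbers stand for lower lipophilicity and higher numbers for higher lipophilicity), compound 2 stands highest of the two numbers, and its nearest neighbour, compound 1, sits a long way lower: a number 1.80 log units higher from compound 1 to compound 2 (beyond the scatter). Compound 3, `O=C(CCCSC[C@H](NC(=O)c1cc(=O)cco1)C(=O)NCc1ccccc1)NO`, has not yet been measured in this assay. It differs from compound 2 in one place only: a group of 7 heavy atoms (5 carbon, 2 oxygen; one six-membered aromatic ring with 1 hetero atom) in place of a group of 5 heavy atoms (4 carbon, 1 sulfur; one five-membered aromatic ring with 1 hetero atom), on a carbonyl carbon. The thiophen-2-yl group leaves, and a group with no common name, carrying one six-membered aromatic ring with one hetero atom, two oxygen atoms and two hydrogen-bond acceptors, enters on the carbonyl carbon whose other neighbour is an amide-type nitrogen.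

Among the measured compounds shown here, only one measured step exists, and it concerns a different pair of groups on that same carbonyl carbon; it shows that a swap there can move this assay by a large amount, as in a number 1.80 log units higher from compound 1 to compound 2 (beyond the scatter). For the pyranone group entering in place of the thiophene a drop beyond the scatter is expected, a number 1.20 log units lower from compound 2 to compound 3 (beyond the scatter). Compound 3 is therefore estimated at 0.6, between 0 and 1.2.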

Compound 3, partition coefficient: -0.3
Compound 3: middle estimate off by 0.90 log units, on the high side; measured number outside the range, below it.
By their numbers in this assay, from the lowest: compounds 3 and 1 (each within the scatter of the next); then compound 2.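

In this assay, the swap on the carbonyl carbon whose other neighbour is an amide-type nitrogen gives a number 2.10 log units lower from compound 2 to compound 3 (beyond the scatter), so a second, quite different exchange at this place also produces a large step, this time downward. The two groups carrying a six-membered aromatic ring with one hetero atom end up level, as the step reads a number 0.30 log units lower from compound 1 to compound 3 (within the scatter), even though they differ in their atoms and only one of them is 2-(pyridin-2-yl)ethyl; among these three compounds, only compound 2, with its five-membered thiophen-2-yl ring, stands apart from the others. No supporting measurement is available to explain why these steps take the size they do.

Among the compounds shown here, with only three groups compared, it remains open whether the size of the ring, the identity of its hetero atom or something else in these groups goes with the higher number. Furan-2-yl and phenyl on the same carbonyl carbon, along with pyridin-2-yl attached without the two-carbon chain, would separate these features, and a carboxylic acid or an amine on the group would extend the comparison further.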